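The compounds below may be only part of what the source reports. "The series", "measured", "known", "first", "only" and "open" are said of these compounds alone.

Compounds measured in an ADME assay on Caco-2 cells (Homo sapiens) for permeability, in the apical to basolateral direction; a higher number here means that the compound crosses the layer faster, a lower number that the compound crosses the layer more slowly:
compound 1, `CCC(=O)N1CCC(CN(C2Cc3cc(C#N)ccc3N(Cc3cncn3C)C2)S(=O)(=O)c2ccccn2)CC1`, 0.5 10^-6 cm/s;
compound 2, `Cn1cncc1CN1CC(N(CC2CCN(C(=O)CC(C)(C)C)CC2)S(=O)(=O)c2ccccn2)Cc2cc(C#N)ccc21`, 0.5 10^-6 cm/s;
compound 3, `CC(C)NC(=O)N1CCC(CN(C2Cc3cc(C#N)ccc3N(Cc3cncn3C)C2)S(=O)(=O)c2ccccn2)CC1`, 0.6 10^-6 cm/s.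

Compound 3 carries the highest of the three numbers, yet a 1.2-fold higher number from compound 1 to compound 3 (0.08 log units; within the scatter) and a 1.2-fold higher number from compound 2 to compound 3 (0.08 log units; within the scatter) both sit within the scatter, so nothing separates it from the other two. Compound 4, `CC(C)C(=O)N1CCC(CN(C2Cc3cc(C#N)ccc3N(Cc3cncn3C)C2)S(=O)(=O)c2ccccn2)CC1`, differs from compound 3 in one place: isopropyl in place of isopropylamino on a carbonyl carbon. Within the data shown here, the steps that bear on it are the earlier exchanges on the same carbonyl carbon, no change at the digits printed from compound 1 to compound 2 (within the scatter) and a 1.2-fold higher number from compound 1 to compound 3 (0.08 log units; within the scatter), neither of which moved the number beyond the scatter. Compound 1 already carries a plain alkyl group at that position and gives 0.5 10^-6 cm/s, so the number for compound 4 is expected close to it. The expected step is a 1.2-fold lower number from compound 3 to compound 4 (0.08 log units; within the scatter), within the scatter. For compound 4 the estimate is 0.5 10^-6 cm/s, range 0.3 10^-6 cm/s to 1 10^-6 cm/s.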

Compound 4, apparent permeability: 0.5 10^-6 cm/s
Compound 4: the middle estimate sits on the measured number at the digits printed; measured number inside the range.
By their numbers in this assay, from the lowest: compounds 1, 2, 4 and 3 (each within the scatter of the next).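

The step from isopropylamino to isopropyl removes the nitrogen and the one hydrogen-bond donor of that group, and a 1.2-fold lower number from compound 3 to compound 4 (0.08 log units; within the scatter) in this assay shows no separation. Isopropyl also joins the other plain alkyl groups on this carbonyl carbon, with no change at the digits printed from compound 1 to compound 4 (within the scatter) and no change at the digits printed from compound 2 to compound 4 (within the scatter) as the readings. So far, neither the presence of that donor nor the size of the alkyl group has moved the number beyond the scatter in these compounds.

From the compounds shown here alone, whether a carboxylic acid, a primary amine or a phenyl ring on that carbonyl carbon would do so stays open. No measurement at hand explains this flat picture.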